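The compounds below may be only part of what the source reports. "The series", "measured", "known", "first", "only" and "open" are said of these compounds alone.

Compound 2 `CN(C)c1nc(/C=C/c2cccc([N+](=O)[O-])c2)nc(Nc2ccc(NC(=O)Nc3ccc(Cl)cc3)cc2)n1` gives 5120 nM in a functional assay on U-87MG ATCC cells for antiproliferative activity against U-87 MG (Homo sapiens), with a stated time of 4 days (a lower number here means a stronger inhibitor, a higher number a weaker inhibitor), the highest of the two numbers in the series; its nearest neighbour is compound 1 `O=C(Nc1ccc(Cl)cc1)Nc1ccc(Nc2nc(/C=C/c3cccc([N+](=O)[O-])c3)nc(N3CC(O)C3)n2)cc1`, which gives 1320 nM, the change being a 3.9-fold higher number from compound 1 to compound 2 (0.59 log units; beyond the scatter). Compound 3 `O=C(Nc1ccc(Cl)cc1)Nc1ccc(Nc2nc(/C=C/c3cccc([N+](=O)[O-])c3)nc(N3CCCC3)n2)cc1` differs from compound 2 by pyrrolidin-1-yl in place of dimethylamino on an aromatic carbon. Among the measured compounds shown here, the only step that bears on this position is the one from compound 1 to compound 2, where an open-chain amine in place of a ring-bearing amine raised the number modestly; the hydroxyl of compound 1 is absent from compound 3, so a smaller return toward compound 1 is expected for compound 3, about a 1.7-fold lower number from compound 2 to compound 3 (0.23 log units; within the scatter), giving an estimated value of 3000 nM with a range of 1000 nM to 9000 nM.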

Compound 3, half-maximal inhibitory concentration: 4470 nM
Compound 3: the middle estimate sits 1.5-fold (0.17 log units) below what was measured, within the range that was stated.
By their numbers in this assay, from the lowest: compound 1; then compounds 3 and 2 (each within the scatter of the next).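

In this assay, pyrrolidin-1-yl in place of dimethylamino gives a 1.1-fold lower number from compound 2 to compound 3 (0.06 log units; within the scatter), so a ring on this amine nitrogen does not by itself separate these two compounds. Pyrrolidin-1-yl in place of 3-hydroxyazetidin-1-yl gives a 3.4-fold higher number from compound 1 to compound 3 (0.53 log units; beyond the scatter), which leaves compound 1 as the only one of the three set apart from the others at this position. No supporting evidence bears on this result. On these data alone, whether the hydroxyl or the smaller ring goes with the lower number of compound 1 remains open; unsubstituted azetidin-1-yl and 3-hydroxypyrrolidin-1-yl would each address this.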